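The compounds below may be only part of what the source reports. "The series", "measured", "known", "first", "only" and "open" are said of these compounds alone.

The measured compounds in a functional assay on DU-145 cells (Homo sapiens) for cytotoxicity, read by MTT assay; a lower number here means a stronger inhibitor, a higher number a weaker inhibitor:
compound 1 `CC(C)=CC[C@@H](OC[C@@H](C)O)C1=CC(=O)c2c(O)ccc(O)c2C1=O` gives 14300 nM;
compound 2 `CC(=O)OCCC(=O)O[C@H](CC=C(C)C)C1=CC(=O)c2c(O)ccc(O)c2C1=O` gives 15700 nM;
compound 3 `CCCCC(O)CC(=O)O[C@H](CC=C(C)C)C1=CC(=O)c2c(O)ccc(O)c2C1=O` gives 45300 nM.

Compound 3 stands at the highest number of the three: the steps of a 3.2-fold higher number from compound 1 to compound 3 (0.50 log units; beyond the scatter) and a 2.9-fold higher number from compound 2 to compound 3 (0.46 log units; beyond the scatter) both lie beyond the scatter, whereas a 1.1-fold higher number from compound 1 to compound 2 (0.04 log units; within the scatter) does not. Compound 4 `CC(C)=CC[C@@H](OC(=O)C1CCCO1)C1=CC(=O)c2c(O)ccc(O)c2C1=O` differs from compound 3 in one place: oxolan-2-yl in place of 2-hydroxyhexyl on a carbonyl carbon. The two steps that altered the group on the carbonyl carbon were modest in size, and the group that enters here has not appeared in any measured compound. Compound 4 is therefore expected to fall among the numbers seen so far, with a step of a 2.3-fold lower number from compound 3 to compound 4 (0.36 log units; beyond the scatter) toward a lower number that may not exceed the scatter. Compound 4 is estimated at 20000 nM, within 8000 nM to 50000 nM.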

Compound 4, half-maximal inhibitory concentration: 10500 nM
Compound 4: middle estimate off by 1.9-fold (0.28 log units), on the high side; the range from low to high includes it.
By their numbers in this assay, from the lowest: compounds 4, 1 and 2 (each within the scatter of the next); then compound 3.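

In this assay, oxolan-2-yl on the carbonyl carbon removes the gap that 2-hydroxyhexyl had opened (a 4.3-fold lower number from compound 3 to compound 4 (0.63 log units; beyond the scatter)), so this position tolerates a ring-bearing group. For the compounds shown here, compound 4 stays level with the other two (a 1.5-fold lower number from compound 2 to compound 4 (0.17 log units; within the scatter) and a 1.4-fold lower number from compound 1 to compound 4 (0.13 log units; within the scatter)), leaving compound 3 as the one weak member of the set. No available evidence accounts for these steps. As far as these compounds go, whether 2-hydroxyhexyl owes its higher number to its hydroxyl or to its chain remains open, as does how a cyclopentyl group or an amine on the carbonyl carbon would compare with oxolan-2-yl.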